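The compounds below may be only part of what the source reports. "The series", "measured", "known", "first", "only" and "open" are said of these compounds alone.

Measured in a functional assay on HT-29 cells (Homo sapiens) for antiproliferative activity, read by sulforhodamine B assay, with a stated time of 48 h; on this read-out higher numbers stand for weaker inhibition and lower numbers for stronger inhibition:
- Compound 1 `CN1CCN(c2ccc(S(=O)(=O)Oc3ccc(F)cc3)cc2)C1=O`: > 100000 nM, a limit
- Compound 2 `CCCN1CCN(c2ccc(S(=O)(=O)Oc3ccccc3CC)cc2)C1=O`: > 100000 nM, a limit
- Compound 3 `CCCN1CCN(c2ccc(S(=O)(=O)Oc3cccc(OC)c3)cc2)C1=O`: 25000 nM

Compound 3 alone carries a number, and the other two stop at the limit of > 100000 nM in this assay, at which 2 of the 3 values shown sit. Compound 4 `CCCN1CCN(c2ccc(S(=O)(=O)Oc3ccc(F)cc3)cc2)C1=O` has 4-fluorophenyl in place of 3-methoxyphenyl on an oxygen. One measured step changes the group at this place, an at least 4.0-fold lower number from compound 2 to compound 3 (0.60 log units; beyond the scatter), so this group can move the read-out beyond the scatter. Compound 1 also carries 4-fluorophenyl, and its value of > 100000 nM is a limit. A modest move toward weaker inhibition is therefore expected. The estimated step is a 1.8-fold higher number from compound 3 to compound 4 (0.26 log units; within the scatter) in this assay. For compound 4 the expected value is 45000 nM, with an estimated range of 12000 nM to 100000 nM.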

Compound 4, half-maximal inhibitory concentration: 23000 nM
The estimate for compound 4 lay 2.0-fold (0.29 log units) above the measured number, within the range that was stated.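

In this assay, 4-fluorophenyl on this oxygen does no differently from 3-methoxyphenyl (a 1.1-fold lower number from compound 3 to compound 4 (0.04 log units; within the scatter)), so two unlike groups here now share one level, while 2-ethylphenyl stands apart (an at least 4.3-fold lower number from compound 2 to compound 4 (0.63 log units; beyond the scatter)). With 4-fluorophenyl held fixed, ethyl in place of hydrogen on the saturated chain carbon bound to the amide-type nitrogen also matters (an at least 4.3-fold lower number from compound 1 to compound 4 (0.63 log units; beyond the scatter)). Both of these larger steps are open-ended, since compounds 1 and 2 are limits: (the limit of > 100000 nM in this assay, at which 2 of the 4 values shown sit).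

Going by these compounds, whether an amine or a carboxylic acid on this phenyl group would shift the number remains open. So does the effect of a longer chain on that nitrogen.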